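The source may report more compounds than this note shows. Statements on the series, on what has been measured and on what is new or still open speak of the compounds shown alone.

For the measured compounds named here, compound 2 `CCSc1n[nH]c(-n2[se]c3ccccc3c2=O)n1` gives 39600 nM in a functional assay on A549 cells (Homo sapiens) for antiproliferative activity, read by CCK-8 assay, with a stated time of 48 h (on this read-out lower numbers stand for stronger inhibition and higher numbers for weaker inhibition), the higher of the two numbers known here, while compound 1 `CCCCSc1n[nH]c(-n2[se]c3ccccc3c2=O)n1` gives 12500 nM. Compound 3 `Cc1ccccc1CSc1n[nH]c(-n2[se]c3ccccc3c2=O)n1` arises from compound 2 by 2-methylphenyl in place of methyl on a saturated chain carbon bound to a sulfur. Going by the values given here, only one measured step bears on this change: a 3.2-fold higher number from compound 1 to compound 2 (0.50 log units; beyond the scatter), in which a shorter chain on the sulfur went with a higher number. Enlarging the chain on the sulfur is therefore expected to lower the number, and the expected shift reads a 4.0-fold lower number from compound 2 to compound 3 (0.60 log units; beyond the scatter). Compound 3 is estimated to give 10000 nM, with a range from 3000 nM to 35000 nM.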

Compound 3, half-maximal inhibitory concentration: 9720 nM
For compound 3 the middle estimate is 1.0-fold (0.01 log units) above the measured one; the measured number falls inside the stated range.
By their numbers in this assay, from the lowest: compounds 3 and 1 (each within the scatter of the next); then compound 2.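

In this assay, 2-methylphenyl in place of methyl on a saturated chain carbon bound to a sulfur gives a 4.1-fold lower number from compound 2 to compound 3 (0.61 log units; beyond the scatter) and shows that an aromatic ring can stand at this position with a lower number than the shortest chain gives. With 2-methylphenyl in place of propyl, the step reads a 1.3-fold lower number from compound 1 to compound 3 (0.11 log units; within the scatter) and leaves the aromatic and open-chain groups indistinguishable here. Nothing available accounts for either step. Open, as far as these compounds go, is whether a longer chain would lower the number further. Also open, from the compounds shown here alone, is how an amine or a carboxylic acid at this position would compare.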